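A few compounds are considered here, and "the series" means these few. Any claim that something is new, unique, unknown or untested is made for them only; others in the source may bear on it.

Working notes on the series, read in a functional assay on SW480 cells (Homo sapiens) for cytotoxicity, read by MTT assay, with a stated time of 4 days; a lower number here means a stronger inhibitor, a higher number a weaker inhibitor. Compound 1, `C=C1C[C@]23C[C@@]1(O)CC[C@@H]2c1cccc(C)c1[C@@H]3Cn1cc(-c2ccc(Br)cc2)nn1`, is the bromo member; in this assay compound 1 gives > 20000 nM, which is a limit of the assay and not a number. Compound 3, `C=C1C[C@]23C[C@@]1(O)CC[C@@H]2c1cccc(C)c1[C@@H]3Cn1cc(-c2ccc(F)cc2)nn1`, differs from it by fluoro in place of bromo on an aromatic carbon; in this assay compound 3 gives > 20000 nM, again a limit. The step that the two limits leave unreadable from compound 1 to compound 3 is therefore unreadable. Compound 2, `Cc1c(O)ccc2c1[C@H](Cn1cc(-c3ccccc3)nn1)[C@@]13CC(=O)[C@@](C)(CC[C@@H]21)C3`, carries an unsubstituted phenyl on a different core. In this assay compound 2 gives > 20000 nM, a limit of the assay. Across the whole set the picture is the same: the limit of > 20000 nM in this assay, at which 3 of the 3 values shown sit.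

Compound 4, `Cc1ccc(-c2cn(C[C@H]3c4c(ccc(O)c4C)[C@@H]4CC[C@@]5(C)C[C@]43CC5=O)nn2)cc1`, differs from compound 2 in one place: methyl in place of hydrogen on an aromatic carbon. Among the measured compounds shown here, no measured step bears on this change; the single step from compound 1 to compound 3 concerns another substituent and is itself unreadable. Compound 2 stands at a limit, so the added methyl gives no grounds to expect a readable number. Compound 4 is estimated at 30000 nM, between 10000 nM and 100000 nM. The step that the limit leaves unreadable from compound 2 to compound 4 is expected to be nothing beyond the scatter, with a limit the likeliest report.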

Compound 4, half-maximal inhibitory concentration: > 20000 nM
Compound 4 was reported as a limit (the forecaster's own chance of this, stated with the estimate: 85%); the middle value is on the limit's open side.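

In this assay compound 4 gives > 20000 nM, a limit and not a number. Compound 2 also stands at a limit, so the step from compound 2 to compound 4 cannot be read. The set shares one result: the limit of > 20000 nM in this assay, at which 4 of the 4 values shown sit. The compounds shown leave open what structural change, if any, would give a readable value.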